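This account rests on a few compounds, and the source may have more. Where it says the series, first, only, none or still open, it means among the compounds named here.

Measured compounds:
Compound 1, `CC(C)(C)n1ncc(OCc2nnc(-c3ccc(Cl)cc3)s2)c(Cl)c1=O`: 106000 nM in a functional assay on the whole organism for inhibition, with Mythimna separata as the target, with a stated time of 5 days; a higher number here means that more compound is needed for the effect, a lower number that less compound is needed
Compound 2, `COc1c(F)c(F)cc(-c2nnc(COc3cnn(C(C)(C)C)c(=O)c3Cl)o2)c1F`: > 299000 nM in this assay

Compound 1 holds the only numerical result in this assay; there compound 1 gives 106000 nM. The result for compound 2 is a limit of the assay rather than a number, and in this assay compound 2 gives > 299000 nM. Of the two values shown, one sits at the limit of > 299000 nM in this assay, at which 1 of the 2 values shown sits, so only compound 1 offers a reference point for the next step.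

Compound 3, `CC(C)(C)n1ncc(OCc2nnc(-c3ccccc3)s2)c(Cl)c1=O`, differs from compound 1 by hydrogen in place of chloro on an aromatic carbon. Among the compounds with values here, no step between measured compounds is available to calibrate this change. A modest loss, close to the edge of the usual scatter, is expected in this assay, namely a 1.9-fold higher number from compound 1 to compound 3 (0.28 log units; within the scatter). Compound 3 is therefore estimated at 200000 nM, within a range from 70000 nM to 600000 nM.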

Compound 3, half-maximal effective concentration: 200000 nM
For compound 3 middle estimate and measured number coincide at the digits printed; low and high end bracket the measured number.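

In this assay, within the data shown here, the change from 4-chlorophenyl to phenyl gives the first step that can be read between two measured compounds (a 1.9-fold higher number from compound 1 to compound 3 (0.28 log units; within the scatter)). Compound 1 and compound 3 therefore cannot be told apart in this assay. At this place on the aromatic ring, para to a large group, hydrogen stands in for chloro with no difference beyond the scatter. Nothing among the data shown bears on why this is so.

Among these compounds, the single step shows only the exchange of chloro for hydrogen, so it remains open whether an amine or a carboxylic acid at the same place would shift the number beyond the scatter. Also open, on these data alone, is whether the shared core would tolerate a longer chain in place of its tert-butyl group.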